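The source may report more compounds than this note shows. Statements on the series, on what has been measured and on what is new or still open speak of the compounds shown alone.

Compound 1 `COc1ncnc2c1c(-c1ccsc1)cn2[C@@H]1O[C@H](CO)[C@@H](O)[C@H]1O` carries a methoxy group and a thiophen-3-yl ring on the shared core. Going by the values given here, in an ADME assay on BJ cells (Homo sapiens), read by MTT assay, with a stated time of 72 h (a lower number here means a stronger inhibitor, a higher number a weaker inhibitor), compound 1 gives 64300 nM, the only plain number reported here. Compound 2 `CN(C)c1ncnc2c1c(-c1ccsc1)cn2[C@@H]1O[C@H](CO)[C@@H](O)[C@H]1O` gives only a limit of the assay, > 100000 nM. Among the compounds with values here, the single measured step, an at least 1.5-fold higher number from compound 1 to compound 2 (0.19 log units; that floor lies within the scatter), concerns the methoxy group and not the thiophen-3-yl ring, so it does not bear on the change to compound 3 `COc1ncnc2c1c(-c1ccoc1)cn2[C@@H]1O[C@H](CO)[C@@H](O)[C@H]1O`, where (furan-3-yl in place of thiophen-3-yl on an aromatic carbon). Within the data shown here, with no measured step on this ring, compound 3 is expected to change little, a step of a 1.1-fold higher number from compound 1 to compound 3 (0.04 log units; within the scatter). Compound 3 is therefore estimated at 70000 nM, with a range from 30000 nM to 160000 nM.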

Compound 3, half-maximal inhibitory concentration: 28800 nM
For compound 3 the middle estimate is 2.4-fold (0.39 log units) above the measured one; the whole stated range lies above it.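

Changing the ring on this aromatic carbon does register: with the same count of heavy atoms, furan-3-yl in place of thiophen-3-yl gives a 2.2-fold lower number from compound 1 to compound 3 (0.35 log units; beyond the scatter) in this assay. The earlier step concerned only the methoxy group, and its floor lay within the scatter, so this is the first step shown that clearly exceeds the scatter. Nothing measured here explains the difference between these two rings.

Still open, from the compounds shown here alone, is how a phenyl ring or a short alkyl chain on this carbon would read. Also open, going by these compounds, is whether the same ring change has a similar effect with dimethylamino in place of methoxy.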